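Alkyl sulfoxide isothiocyanates: branching the group on sulfur

A few compounds are considered here, and "the series" means these few. Any claim that something is new, unique, unknown or untested is made for them only; others in the source may bear on it.

Values in a functional assay on A549 cells (Homo sapiens) for cytotoxicity, read by MTT assay, with a stated time of 72 h (a higher number here means a weaker inhibitor, a lower number a stronger inhibitor), for the measured compounds:

compound 1 `S=C=NCCCCSCc1ccccc1`: 51300 nM
compound 2 `CCC[S+]([O-])CCCCN=C=S`: 10700 nM
compound 3 `CCCC[S+]([O-])CCCCN=C=S`: 9560 nM

Compound 2 holds the second highest of the three numbers in this assay. Compound 3 stands nearest to it; the step between the two is a 1.1-fold lower number from compound 2 to compound 3 (0.05 log units; within the scatter). Among the compounds with values here, compound 1 stands furthest away: the two values show compound 1 at a higher number than compound 2, beyond the scatter, though no step joins them directly.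

Compound 4 `CC(C)[S+]([O-])CCCCN=C=S` has not yet been measured in this assay. Against compound 2 the change is isopropyl in place of propyl on a sulfur. Within the data shown here, the only measured step that touches the alkyl group on the sulfur is the one in which methyl replaces hydrogen on a saturated chain carbon three bonds along the chain from a sulfur, and it gave a 1.1-fold lower number from compound 2 to compound 3 (0.05 log units; within the scatter), within the scatter. Among the measured compounds shown here, no measured pair shows a branched group on the sulfur, so the expectation rests on that one step alone, and no move beyond the scatter is expected. For compound 4 the expected step in this assay is a 1.0-fold lower number from compound 2 to compound 4 (0.01 log units; within the scatter). Compound 4 is estimated at 10500 nM, expected to lie between 4500 nM and 24000 nM.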

Compound 4, half-maximal inhibitory concentration: 10400 nM
Compound 4: the middle estimate sits 1.0-fold (0.00 log units) above what was measured, within the range that was stated.
By their numbers in this assay, from the lowest: compounds 3, 4 and 2 (each within the scatter of the next); then compound 1.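

In this assay, within the data shown here, the earlier compounds showed only that a straight propyl and a straight butyl on the sulfur could not be told apart; the new result extends this to branching at the same position, with the three carbons of propyl rejoined as isopropyl (a 1.0-fold lower number from compound 2 to compound 4 (0.01 log units; within the scatter)). The comparison with the longer straight group gives the same picture (a 1.1-fold higher number from compound 3 to compound 4 (0.04 log units; within the scatter)), so compounds 2, 3 and 4 form one group of values, and neither chain length nor this branching separates them here. No supporting data are available to explain this flat result.

Still open, going by these compounds, is whether another branched group such as tert-butyl, a ring such as cyclohexyl, or a chain ending in an amine or a carboxylic acid would stay with these three values. A benzyl group on the sulfoxide sulfur would also show how compound 1 relates to this group, since compound 1 differs from compounds 2, 3 and 4 in more than one place.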